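This account rests on a few compounds, and the source may have more. Where it says the series, first, only, none or still open, it means among the compounds named here.

Compound 3 `CNc1cc(-c2c(C)nn(-c3nc(-c4ccc(Cl)c(Cl)c4)c(SC(C)C)s3)c2C(=O)O)ccn1` holds the second highest of the three numbers: in a functional assay on BJAB cells (Homo sapiens) for antiproliferative activity, with a stated time of 4 days (on this read-out higher numbers stand for an effect only at larger amounts of compound and lower numbers for an effect already at smaller amounts), compound 3 gives 18000 nM. Its nearest neighbour is compound 1 `Cc1nn(-c2nc(-c3ccc(Cl)c(Cl)c3)c(SC(C)C)s2)c(C(=O)O)c1-c1cncnc1`, which gives 22000 nM, so that a 1.2-fold lower number from compound 1 to compound 3 (0.09 log units; within the scatter). Compound 2 `Cc1cc(-c2c(C)nn(-c3nc(-c4ccc(Cl)c(Cl)c4)c(SC(C)C)s3)c2C(=O)O)cc(C)n1` gives 580 nM, and a 31-fold higher number from compound 2 to compound 3 (1.49 log units; beyond the scatter). Compound 4 `CCOc1ncccc1-c1c(C)nn(-c2nc(-c3ccc(Cl)c(Cl)c3)c(SC(C)C)s2)c1C(=O)O` changes the same aromatic group: 2-ethoxypyridin-3-yl in place of 2-(methylamino)pyridin-4-yl on an aromatic carbon. Within the data shown here, the steps that bear on this are a 38-fold lower number from compound 1 to compound 2 (1.58 log units; beyond the scatter) and a 31-fold higher number from compound 2 to compound 3 (1.49 log units; beyond the scatter), both large, showing that the group on this aromatic carbon can move the number widely, while compound 1 and compound 3 sit close together. Compound 4 carries a ring unlike either of those, so its number is uncertain; a moderate lowering is expected, a 2.0-fold lower number from compound 3 to compound 4 (0.30 log units; within the scatter). Compound 4 is estimated at 9000 nM, within 1500 nM to 40000 nM.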

Compound 4, half-maximal effective concentration: 11000 nM
Estimate against measurement, compound 4: 1.2-fold (0.09 log units) below; the range from low to high includes it.
By their numbers in this assay, from the lowest: compound 2; then compounds 4, 3 and 1 (each within the scatter of the next).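

In this assay the 2-ethoxypyridin-3-yl group lands with the pyrimidin-5-yl and 2-(methylamino)pyridin-4-yl groups (a 2.0-fold lower number from compound 1 to compound 4 (0.30 log units; within the scatter); a 1.6-fold lower number from compound 3 to compound 4 (0.21 log units; within the scatter)). The 2,6-dimethylpyridin-4-yl group of compound 2 therefore remains the only one apart among these rings on this aromatic carbon (a 19-fold higher number from compound 2 to compound 4 (1.28 log units; beyond the scatter)). Nothing measured here accounts for this. Open, going by these compounds, is whether a single methyl on the pyridin-4-yl ring, or a plain phenyl ring, would track compound 2 or the other three. Also open, on these data alone, is what a longer chain in place of the ethoxy group would give.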